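Swapping Phenyl for Acetyl on a Shared Core

The compounds below may be only part of what the source reports. "The series", "measured", "known", "first", "only" and "open" are said of these compounds alone.

Compound 1 `NS(=O)(=O)c1ccc(-c2nc3cc([N+](=O)[O-])ccc3[nH]2)cc1`: in a functional assay for antagonist activity at Neuropeptides B/W receptor type 1 (Homo sapiens), read by cAMP accumulation (on this read-out lower numbers stand for stronger inhibition and higher numbers for weaker inhibition), compound 1 gives > 31600 nM, which is a limit of the assay and not a number.
Compound 2 `O=[N+]([O-])c1ccc2[nH]c(-c3ccc(-c4ccccc4)cc3)nc2c1`: in this assay compound 2 gives 4880 nM.

Among the compounds with values here, compound 2 thus holds the only true number here; the other value is a limit. Compound 3 `CC(=O)c1ccc(-c2nc3cc([N+](=O)[O-])ccc3[nH]2)cc1` differs from compound 2 in one place: acetyl in place of phenyl on an aromatic carbon. Within the data shown here, the one measured step, an at least 6.4-fold lower number from compound 1 to compound 2 (0.81 log units; beyond the scatter), shows that putting a phenyl where a sulfamoyl had been gave a clearly stronger result. Acetyl brings no ring and one hydrogen-bond acceptor, closer to what compound 1 carried than to the phenyl of compound 2, so compound 3 is expected to weaken, a step of a 3.1-fold higher number from compound 2 to compound 3 (0.49 log units; beyond the scatter). Compound 3 is estimated at 15000 nM, within 4000 nM to 60000 nM.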

Compound 3, half-maximal inhibitory concentration: 9320 nM
Estimate against measurement, compound 3: 1.6-fold (0.21 log units) above, and the stated range covers the measured number.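

Replacing the phenyl with acetyl removes the ring, yet this assay shows a 1.9-fold higher number from compound 2 to compound 3 (0.28 log units; within the scatter), so among these compounds a ring at this position is not needed to obtain a measurable number. Acetyl in place of sulfamoyl gives an at least 3.3-fold lower number from compound 1 to compound 3 (0.53 log units; beyond the scatter), so the smaller acetyl also gives a clear gain over sulfamoyl, as phenyl did. This comparison rests on compound 1, whose value is a limit and not a number: the limit of > 31600 nM in this assay, at which 1 of the 3 values shown sits.

The compounds shown leave open what a plain methyl, an amine or a carboxylic acid would give at this position.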